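Working notes: chloro in place of methyl on compound 2

A few compounds are considered here, and "the series" means these few. Any claim that something is new, unique, unknown or untested is made for them only; others in the source may bear on it.

Measured so far in a functional assay on M21 cells (Homo sapiens) for antiproliferative activity, read by sulforhodamine B assay, with a stated time of 48 h; a higher number here means a weaker inhibitor, a lower number a stronger inhibitor
compound 1 `CN1CCN(c2ccc(S(=O)(=O)Oc3cccc(Cl)c3)cc2)C1=O` gives 1600 nM
compound 2 `CCCN1CCN(c2ccc(S(=O)(=O)Oc3cccc(C)c3)cc2)C1=O` gives 28000 nM

Compound 2 holds the higher of the two numbers, beyond the scatter from compound 1. Compound 3 `CCCN1CCN(c2ccc(S(=O)(=O)Oc3cccc(Cl)c3)cc2)C1=O` is compound 2 with chloro in place of methyl on an aromatic carbon. Among the compounds with values here, no single-place step between measured compounds is available. Compound 1 (1600 nM) carries the 3-chlorophenyl group but also differs in its chain, so it gives only a loose guide. A moderate step to a lower number, beyond the scatter, is expected in this assay (a 4.7-fold lower number from compound 2 to compound 3 (0.67 log units; beyond the scatter)). Compound 3 is estimated at 6000 nM (range 1500 nM to 20000 nM).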

Compound 3, half-maximal inhibitory concentration: 8600 nM
For compound 3 the middle estimate is 1.4-fold (0.16 log units) below the measured one, within the range that was stated.
By their numbers in this assay, from the lowest: compound 1; then compound 3; then compound 2.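

In this assay, 3-chlorophenyl in place of 3-methylphenyl, with the chain held constant, gives a 3.3-fold lower number from compound 2 to compound 3 (0.51 log units; beyond the scatter), so this position alone moves the number beyond the scatter. With the 3-chlorophenyl group held, ethyl in place of hydrogen on the chain carbon gives a 5.4-fold higher number from compound 1 to compound 3 (0.73 log units; beyond the scatter), so the chain change also moves the number beyond the scatter, and in the direction of a weaker inhibitor. Nothing measured here accounts for either step. Still open, on these data alone, is how a methoxy, a nitrile or a bromo at this position would read. Also open, as far as these compounds go, is how a carboxylic acid or an amine on the chain would read.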